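The source may report more compounds than this note shows. Statements on the series, on what has been measured and on what is new or still open speak of the compounds shown alone.

Of the compounds shown here, three have been tested for how much of them cultured mouse cells tolerate, and a fourth is still open. Compound 1 `O=c1oc2ccc(Cl)cc2c(=O)n1-c1ccc(Cl)cc1F` and compound 2 `O=c1oc2ccc(I)cc2c(=O)n1-c1ccc(Cl)cc1F` share one core; compound 3 `O=C(Nc1ccc(Cl)cc1F)c1cc(F)ccc1O` and compound 4 `O=C(Nc1ccc(I)cc1F)c1cc(F)ccc1O` share another. How the two cores differ is not broken down here.

In an ADME assay on RAW264.7 cells (Mus musculus) for cytotoxicity, read by MTT assay, with a stated time of 24 h (a higher number here means that more compound is tolerated, a lower number that less compound is tolerated), compound 1 gives 6800 nM. In this assay compound 2 gives 8900 nM, so the change iodo in place of chloro on an aromatic carbon brought a 1.3-fold higher number from compound 1 to compound 2 (0.12 log units; within the scatter). In this assay compound 3 gives 7700 nM, a number that sits among those of compound 1 and compound 2 without any of the gaps reaching beyond the usual scatter.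

Compound 4 carries the same kind of change relative to compound 3, namely (iodo in place of chloro on an aromatic carbon). Within the data shown here, it is not the same change as the one from compound 1 to compound 2: there the carbon lay in a ring that is part of a fused or bridged system of two rings, meta and para to a fused ring, while here it lies in a six-membered aromatic ring of carbon only, meta to a fluoro group and para to a large group.

Resting on the value of compound 3 7700 nM and on the earlier step of a 1.3-fold higher number from compound 1 to compound 2 (0.12 log units; within the scatter), the step from compound 3 to compound 4 is expected to be a 1.2-fold higher number from compound 3 to compound 4 (0.09 log units; within the scatter), which stays within the scatter. Compound 4 is therefore estimated at 9500 nM, with a plausible range from 4500 nM to 19000 nM.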

Compound 4, half-maximal cytotoxic concentration: 7400 nM
Estimate against measurement, compound 4: 1.3-fold (0.11 log units) above, and the stated range covers the measured number.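

In this assay the swap of chloro for iodo on the core of compound 3 gives a 1.0-fold lower number from compound 3 to compound 4 (0.02 log units; within the scatter) and so makes no difference that repeated measurements could tell apart. This does not prove that the swap is without effect on every core: only two pairs are shown, the carbon that changes lies in a different setting in each, and a small real difference could stay hidden inside the scatter. What can be said is that, for these two pairs, the swap carries from one core to the other without a visible shift in how much compound the cells tolerate, and the two steps agree: the same change on two cores in this assay, a 1.3-fold higher number (0.12 log units; within the scatter) from compound 1 to compound 2 and a 1.0-fold lower number (0.02 log units; within the scatter) from compound 3 to compound 4, 1.4-fold (0.13 log units) apart, within the scatter of two such steps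

The compounds shown exchange only chloro and iodo at this place, so it stays open whether a group of another kind there, such as an amine, a carboxylic acid or a longer chain, would move the number beyond the scatter. As far as these compounds go, it also stays open whether the same swap would behave alike on a third core or in cells other than these mouse cells.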